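The source may hold more compounds than are shown below. What is called first, only, known or untested is meant among the compounds shown, and "the series" means these compounds.

Three compounds have so far been measured in a functional assay on BJAB cells (Homo sapiens) for antiproliferative activity, with a stated time of 4 days; on this read-out higher numbers stand for an effect only at larger amounts of compound and lower numbers for an effect already at smaller amounts:

Compound 1, `Cc1ccc(-c2c(C)nn(-c3nc(-c4ccc(Cl)c(Cl)c4)c(SC(C)C)s3)c2C(=O)O)cc1`, gives 3800 nM.
Compound 2, `Cc1nn(-c2nc(-c3ccc(Cl)c(Cl)c3)c(SC(C)C)s2)c(C(=O)O)c1-c1cncnc1`, gives 22000 nM.
Compound 3, `COc1ccccc1-c1c(C)nn(-c2nc(-c3ccc(Cl)c(Cl)c3)c(SC(C)C)s2)c1C(=O)O`, gives 14700 nM.

Compound 3 stands second highest of these three numbers. Its nearest neighbour is compound 2, and the step between them, a 1.5-fold lower number from compound 2 to compound 3 (0.18 log units; within the scatter), lies within the scatter of repeated measurements, so the two cannot be told apart. Compound 1 is further off, with a 3.9-fold higher number from compound 1 to compound 3 (0.59 log units; beyond the scatter), a modest but real difference.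

Compound 4, `COc1cc(C#N)cc(-c2c(C)nn(-c3nc(-c4ccc(Cl)c(Cl)c4)c(SC(C)C)s3)c2C(=O)O)c1`, is the next compound to be tested. It differs from compound 3 in one place: 3-cyano-5-methoxyphenyl in place of 2-methoxyphenyl on an aromatic carbon. The same aromatic group has already been swapped twice among the measured compounds, with a 5.8-fold higher number from compound 1 to compound 2 (0.76 log units; beyond the scatter) and a 3.9-fold higher number from compound 1 to compound 3 (0.59 log units; beyond the scatter), both modest steps beyond the scatter, while the third swap, a 1.5-fold lower number from compound 2 to compound 3 (0.18 log units; within the scatter), changed nothing that can be trusted. Exchanging this group therefore tends to move the number only modestly. For the measured compounds named here, no measured compound carries a nitrile, so the direction cannot be read from the data; the expected step in this assay is a 1.2-fold lower number from compound 3 to compound 4 (0.09 log units; within the scatter). Compound 4 is estimated to give 12000 nM, within a range from 4000 nM to 40000 nM.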

Compound 4, half-maximal effective concentration: 5200 nM
Beside the measured number, compound 4's estimate is 2.3-fold (0.36 log units) above it; low and high end bracket the measured number.
By their numbers in this assay, from the lowest: compounds 1 and 4 (each within the scatter of the next); then compounds 3 and 2 (each within the scatter of the next).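

In this assay, the position on the five-membered ring that carries these aromatic groups accepts 3-cyano-5-methoxyphenyl without a readable change from 4-methylphenyl, the step being a 1.4-fold higher number from compound 1 to compound 4 (0.14 log units; within the scatter) and so no more than repeat measurements would give. The same group does separate from the other two, with a 2.8-fold lower number from compound 3 to compound 4 (0.45 log units; beyond the scatter) and a 4.2-fold lower number from compound 2 to compound 4 (0.63 log units; beyond the scatter) both showing that a nitrile-bearing ring can sit with the lower numbers, and since compound 3 and compound 4 each carry a methoxy group, having one does not by itself set the number here. Nothing measured alongside these cell results explains the differences.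

Going by these compounds, the swap from compound 3 to compound 4 adds a nitrile and also moves the methoxy group, so the share of each in that step stays unknown, and a phenyl ring carrying only a nitrile would be needed to pull them apart. On these data alone, how an amine or a longer chain on this ring would read in this assay also stays open.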